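Ester groups on the shared core: the cyclohexyl case

This account rests on a few compounds, and the source may have more. Where it says the series, first, only, none or still open, it means among the compounds named here.

Two esters of the shared core have been measured so far. In a functional assay on RAW264.7 cells (Mus musculus) for inhibition, read by ELISA, with a stated time of 24 h (a lower number here means that less compound is needed, a higher number that more compound is needed for the effect), compound 1 `CC/C=C\C[C@H]1C(=O)C=C[C@H]1CC(=O)OCCO` gives 24000 nM and compound 2 `CC/C=C\C[C@H]1C(=O)C=C[C@H]1CC(=O)OC(C)COC` gives 23000 nM. These two values lie within the scatter of each other, so compound 2 stands level with compound 1 and holds no rank of its own.

The structural change to compound 3 `CC/C=C\C[C@H]1C(=O)C=C[C@H]1CC(=O)OC1CCCCC1` is cyclohexyl in place of 1-(methoxymethyl)ethyl on an oxygen next to a carbonyl group.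

For the measured compounds named here, one measured step bears on this change: a 1.0-fold lower number from compound 1 to compound 2 (0.02 log units; within the scatter). It exchanged one group at the same place for another and stayed within the scatter. From the compounds shown here alone, it is thin evidence, as neither compound 1 nor compound 2 has a ring in that group, and the effect of a ring there remains untested. With that single step as the guide, no shift beyond the scatter is expected in this assay, and the expected step is a 1.3-fold lower number from compound 2 to compound 3 (0.11 log units; within the scatter). For compound 3 the estimated value is 18000 nM, with an expected range from 7000 nM to 45000 nM.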

Compound 3, half-maximal effective concentration: 22000 nM
The estimate for compound 3 lay 1.2-fold (0.09 log units) below the measured number; the range from low to high includes it.
By their numbers in this assay, from the lowest: compounds 3, 2 and 1 (each within the scatter of the next).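

In this assay, the ring enters this place without moving the number beyond the scatter: the step is a 1.0-fold lower number from compound 2 to compound 3 (0.02 log units; within the scatter). Set against the 2-hydroxyethyl ester, the result is the same, at a 1.1-fold lower number from compound 1 to compound 3 (0.04 log units; within the scatter), so all three groups on the oxygen next to the carbonyl group stand level, and the earlier question of a ring there now has one answer for cyclohexyl. Going from 1 hydrogen-bond acceptor to 0 in the group, and from no ring to one six-membered non-aromatic ring of carbon only, thus leaves the read-out within the scatter for this pair, and no measurement at hand accounts for the level values.

Still open, from the compounds shown here alone, is whether any group at this place moves the number beyond the scatter at all, for instance a phenyl ring, an amine on the ester chain, a carboxylic acid at the end of a longer chain. Also open, going by these compounds, is how much of the level shared by these three esters belongs to the shared core rather than to the group on the oxygen.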